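This account rests on a few compounds, and the source may have more. Where it says the series, first, only, none or still open, it means among the compounds named here.

Of the compounds shown here, two carry the same core and have been tested so far. Compound 1 `COc1ccc(Cl)cc1N1CCN(C(=O)c2oc(C)nc2-c2ccccc2F)CC1` has a fluorine on the aryl ring that hangs from the oxazole, and in a functional assay on HL-60 cells (Homo sapiens) for inhibition, read by MTT assay, with a stated time of 72 h (a lower number here means a stronger inhibitor, a higher number a weaker inhibitor), compound 1 gives 153 nM. Compound 2 `Cc1ccc(N2CCN(C(=O)c3oc(C)nc3-c3ccccc3)CC2)c(C)c1` lacks that fluorine and bears a dimethylphenyl on the piperazine nitrogen; in this assay compound 2 gives 101 nM. Of the two numbers, compound 2's is the smaller, but the gap to compound 1 lies within the scatter of repeated measurements, so neither can be called the stronger inhibitor.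

Compound 3 `Cc1nc(-c2ccccc2)c(C(=O)N2CCN(c3c(C)cccc3C)CC2)o1` is built from exactly the same atoms as compound 2 but with a different pattern on the aryl ring: 2,6-dimethylphenyl in place of 2,4-dimethylphenyl on an amine nitrogen in a ring. Among the compounds with values here, no measured pair in this set shows what moving a methyl on that ring does, so there is nothing to lean on beyond the two numbers above. The expectation is a step from compound 2 to compound 3 of a 1.5-fold higher number from compound 2 to compound 3 (0.17 log units; within the scatter), that is, nothing clearly beyond the scatter in either direction. In this assay compound 3 is therefore estimated at 150 nM, with a likely range from 60 nM to 400 nM.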

Compound 3, half-maximal inhibitory concentration: 146 nM
Estimate against measurement, compound 3: 1.0-fold (0.01 log units) above; the range from low to high includes it.
By their numbers in this assay, from the lowest: compounds 2, 3 and 1 (each within the scatter of the next).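

Within the data shown here, compound 2 and compound 3 are the first pair here that differ in one place, which gives a first direct look at the aryl ring on the amine nitrogen of the piperazine. In this assay, 2,6-dimethylphenyl in place of 2,4-dimethylphenyl gives a 1.4-fold higher number from compound 2 to compound 3 (0.16 log units; within the scatter), so moving one methyl around this ring, with the atom count unchanged, produces no difference that can be told apart from ordinary repeat-to-repeat variation. Nothing in the data at hand offers a measured reason for this result, and a step this small leaves little to explain in any case.

This single pair tests only where a methyl sits, so it cannot say whether the position would accept a very different group, such as an amine or a carboxylic acid, or a longer chain in place of a methyl. Compound 1 differs from both of the others in more than one place, so the fluorine on its aryl ring cannot yet be judged on its own.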